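An Amino Group Added to Compound 2

The source may hold more compounds than are shown below. What is called first, only, known or untested is meant among the compounds shown, and "the series" means these compounds.

Compound 1 `O=c1nc(O)ccn1[C@@H]1S[C@H](CO)C=C1F` gives > 100000 nM in an ADME assay on CCRF-CEM cells (Homo sapiens) for cytotoxicity (on this read-out lower numbers stand for stronger inhibition and higher numbers for weaker inhibition), which is a limit of the assay and not a number. Compound 2 `O=c1[nH]cnc2c1ncn2[C@@H]1S[C@H](CO)C=C1F` gives > 100000 nM in this assay, which is also a limit. Both compounds therefore sit at the same ceiling, (the limit of > 100000 nM in this assay, at which 2 of the 2 values shown sit), and compound 2 has no exact value to build on. Compound 3 `Nc1nc2c(ncn2[C@@H]2S[C@H](CO)C=C2F)c(=O)[nH]1` has amino in place of hydrogen on an aromatic carbon, between two ring nitrogen atoms (amino in place of hydrogen on an aromatic carbon). Within the data shown here, no measured pair shows what this change does. In this assay, I therefore expect no step beyond the usual scatter, with compound 3 staying close to the ceiling seen for compound 2. The expected size of the change is a number no higher from compound 2 to compound 3 (the limit leaves the size open). For compound 3, the estimated value is 100000 nM, with an expected range from 30000 nM to 200000 nM.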

Compound 3, half-maximal inhibitory concentration: > 100000 nM
Compound 3 gave a limit, no number; the forecaster's own chance of this, stated with the estimate: 75%; the middle value sits exactly at the limit.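

The step from compound 2 to compound 3 cannot be read in this assay, as both compounds give only a limit of the assay and not a number: the limit of > 100000 nM in this assay, at which 3 of the 3 values shown sit. The compounds shown leave open whether amino in place of hydrogen changes this read-out at all.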